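The compounds below may be only part of what the source reports. "The series", "measured", "known", "first", "only" and "open" are said of these compounds alone.

Measured so far:
compound 1, `CNC(=O)c1cc(Oc2ccc(NC(=O)c3cc4cccnc4n(-c4ccccc4)c3=O)cc2)ccn1`, in a functional assay on HT-29 cells (Homo sapiens) for antiproliferative activity, read by MTT assay, with a stated time of 72 h (on this read-out higher numbers stand for weaker inhibition and lower numbers for stronger inhibition), compound 1 gives 250 nM;
compound 2, `CCCNC(=O)c1cc(Oc2ccc(NC(=O)c3cc4cccnc4n(-c4ccccc4)c3=O)cc2)ccn1`, in this assay compound 2 gives 98 nM.

Compound 2 holds the lowest of the two numbers; the nearest is compound 1, and the gap between them is a 2.6-fold lower number from compound 1 to compound 2 (0.41 log units; beyond the scatter).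

Compound 3, `CCCNC(=O)c1cc(Oc2ccc(NC(=O)c3cc4cccnc4n(-c4ccc(Br)cc4F)c3=O)cc2)ccn1`, has not yet been measured. It differs from compound 2 in one place: 4-bromo-2-fluorophenyl in place of phenyl on an aromatic nitrogen.

For the measured compounds named here, only one step has been measured here, a 2.6-fold lower number from compound 1 to compound 2 (0.41 log units; beyond the scatter), and it concerns a different part of the molecule, the saturated chain on the amide-type nitrogen. Going by the values given here, no measured step touches the group on the aromatic nitrogen, so nothing observed says whether a 4-bromo-2-fluorophenyl in place of phenyl will move the number, or in which direction. The expectation is therefore a step of a 1.4-fold lower number from compound 2 to compound 3 (0.15 log units; within the scatter), not clearly beyond the scatter. Compound 3 is estimated at 70 nM, within a range from 25 nM to 250 nM.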

Compound 3, half-maximal inhibitory concentration: 2160 nM
The estimate for compound 3 lay 31-fold (1.49 log units) below the measured number, and the stated range ends below it.
By their numbers in this assay, from the lowest: compound 2; then compound 1; then compound 3.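

In this assay, the group on the aromatic nitrogen proves to be a sensitive position: 4-bromo-2-fluorophenyl in place of phenyl gives a 22-fold higher number from compound 2 to compound 3 (1.34 log units; beyond the scatter), a much larger step than the one on the saturated chain, a 2.6-fold lower number from compound 1 to compound 2 (0.41 log units; beyond the scatter). Both groups share the same six-membered aromatic ring of carbon only, so the change amounts to adding fluorine and bromine to that ring, and this addition is clearly not tolerated here. Nothing measured explains why the step is so large.

Both halogens enter together, so the shares of bromine and fluorine in this step cannot be separated. Going by these compounds, it also remains open how a phenyl carrying only fluorine, only bromine, or an amine would compare with compound 2.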